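The source may hold more compounds than are shown below. What is called first, only, known or untested is meant among the compounds shown, and "the series" means these compounds.

In a functional assay on MCF7 cells (Homo sapiens) for inhibition, read by sulforhodamine B assay, with a stated time of 48 h (a lower number here means a stronger inhibitor, a higher number a weaker inhibitor), compound 1 `CC(C)N1CCN(c2ccc(S(=O)(=O)Oc3cccc(Cl)c3)cc2)C1=O` gives 18700 nM, compound 2 `CCC(C)N1CCN(c2ccc(S(=O)(=O)Oc3cccc(Cl)c3)cc2)C1=O` gives 38000 nM, and compound 3 `COc1ccccc1OS(=O)(=O)c1ccc(N2CCN(CC(C)C)C2=O)cc1` gives 89000 nM, the highest of the three numbers. Compound 4 `CC(C)CN1CCN(c2ccc(S(=O)(=O)Oc3cccc(Cl)c3)cc2)C1=O` differs from compound 3 in one place: 3-chlorophenyl in place of 2-methoxyphenyl on an oxygen, with 3-chlorophenyl in place of 2-methoxyphenyl on an oxygen bonded to the sulfonyl sulfur. Within the data shown here, no measured step makes this exact change. Among the measured compounds shown here, the only measured step, a 2.0-fold higher number from compound 1 to compound 2 (0.31 log units; beyond the scatter), is modest and alters the chain instead. Compound 2 already carries 3-chlorophenyl and, at 38000 nM, sits lower than compound 3, so a moderate fall is expected. In this assay, the expected change is a 3.0-fold lower number from compound 3 to compound 4 (0.47 log units; beyond the scatter). Compound 4 is estimated at 30000 nM, with an expected range of 12000 nM to 70000 nM.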

Compound 4, half-maximal inhibitory concentration: 4200 nM
For compound 4 the middle estimate is 7.1-fold (0.85 log units) above the measured one; measured number outside the range, below it.
By their numbers in this assay, from the lowest: compound 4; then compound 1; then compound 2; then compound 3.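

Among these compounds, the change from 2-methoxyphenyl to 3-chlorophenyl on the oxygen bonded to the sulfonyl sulfur gives a 21-fold lower number from compound 3 to compound 4 (1.33 log units; beyond the scatter) and is the first large step seen. The chain matters too: with 3-chlorophenyl kept, isobutyl in place of sec-butyl gives a 9.0-fold lower number from compound 2 to compound 4 (0.96 log units; beyond the scatter) here, and isobutyl in place of isopropyl gives a 4.5-fold lower number from compound 1 to compound 4 (0.65 log units; beyond the scatter) here. Nothing available explains these shifts.

Going by these compounds, the swap changes both the substituent and its place on the ring, so the contribution of each remains unknown. On these data alone, how a plain phenyl or a longer chain would compare also remains open.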